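The compounds below may be only part of what the source reports. "The series", "measured", "known", "first", "only" and "open" are said of these compounds alone.

Working notes on the series. In a functional assay on MC-38 cells (Mus musculus) for antiproliferative activity, read by CCK-8 assay, with a stated time of 48 h (on this read-out higher numbers stand for weaker inhibition and lower numbers for stronger inhibition), compound 1 (`COc1ccc(/C=C\c2cc(OC)c(OC)c(OC)c2)cc1OCc1ccc(CNC(C)(C)C(=O)O)cc1`) reads > 10000 nM as a limit and not a number. Compound 2 (`COc1ccc(/C=C\c2cc(OC)c(OC)c(OC)c2)cc1OCc1ccc(CN[C@H](C(=O)O)[C@H](C)O)cc1`) also reads > 10000 nM as a limit. Compound 3 (`COc1ccc(/C=C\c2cc(OC)c(OC)c(OC)c2)cc1OCc1ccc(CNCCO)cc1`) gives 1200 nM and is the only one of the three with an actual number.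

Compound 4 (`COc1ccc(/C=C\c2cc(OC)c(OC)c(OC)c2)cc1OCc1ccc(CNCCN(C)C)cc1`) alters the side chain of compound 3 (dimethylamino in place of hydroxy on a saturated chain carbon, two bonds along the chain from an amine nitrogen), with dimethylamino in place of hydroxy on a saturated chain carbon, two bonds along the chain from an amine nitrogen.

For the measured compounds named here, two measured steps concern the same substituent on the amine nitrogen and end at 2-hydroxyethyl (an at least 8.3-fold lower number from compound 1 to compound 3 (0.92 log units; beyond the scatter); an at least 8.3-fold lower number from compound 2 to compound 3 (0.92 log units; beyond the scatter)). Each starts from a limit and removes a carboxy-bearing group, so neither shows what replacing the hydroxy does. The estimate therefore stays anchored on compound 3 (1200 nM).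

The expected step is small (a 1.2-fold lower number from compound 3 to compound 4 (0.08 log units; within the scatter)), with no shift beyond the scatter anticipated in either direction. Compound 4 is estimated at 1000 nM in this assay with an expected range of 300 nM to 4000 nM for this value.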

Compound 4, half-maximal inhibitory concentration: 1400 nM
Compound 4: the middle estimate sits 1.4-fold (0.15 log units) below what was measured, within the range that was stated.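

In this assay, dimethylamino in place of hydroxy on a saturated chain carbon, two bonds along the chain from an amine nitrogen, gives a 1.2-fold higher number from compound 3 to compound 4 (0.07 log units; within the scatter), so at this place the hydrogen-bond donor of the hydroxy can be exchanged with no shift beyond the scatter. The advantage over the carboxy-bearing side chains also holds for this second end group, with an at least 7.1-fold lower number from compound 2 to compound 4 (0.85 log units; beyond the scatter) and an at least 7.1-fold lower number from compound 1 to compound 4 (0.85 log units; beyond the scatter). Both of those steps start from a limit and give only a bound on their size: the limit of > 10000 nM in this assay, at which 2 of the 4 values shown sit.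

Still open, going by these compounds, is whether any end group is needed on this chain, which a plain ethyl would address, and how a longer chain carrying the dimethylamino would read. Also open, on these data alone, is whether the carboxylic acid alone accounts for the gap, which an unbranched chain ending in a carboxylic acid would separate from the branching in compound 1 and compound 2.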